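Fluorine on the phenyl ring of a dopamine receptor agonist

This account rests on a few compounds, and the source may have more. Where it says the series, first, only, none or still open, it means among the compounds named here.

Measured so far:
compound 1 `Cc1cccc(NC(=O)CN2CCC(c3ccccc3C#N)CC2)c1` 71%
compound 2 `Cc1cccc(NC(=O)CN2CCC(c3ccccc3)CC2)c1` 37%

In a functional assay on HEK293 cells for agonist activity at D(4) dopamine receptor (Homo sapiens), read by FLIPR (a higher number here means a larger maximal response, a lower number a smaller maximal response), compound 1 gives 71%. In this assay, among the measured compounds shown here, compound 2 gives 37%, the lower of the two numbers measured so far; the change a number 34 percentage points lower from compound 1 to compound 2 (beyond the scatter) is beyond the scatter and came with hydrogen in place of cyano on an aromatic carbon. Compound 3 `Cc1cccc(NC(=O)CN2CCC(c3cccc(F)c3)CC2)c1` differs from compound 2 by fluoro in place of hydrogen on an aromatic carbon. For the measured compounds named here, the only measured step that bears on it is the loss of the cyano group from compound 1 to compound 2, which was large, but it removed a different group at a different place, so it offers no direct guide to the entry of a fluoro group. A modest step in this assay is therefore expected, most likely upward, as a number 8 percentage points higher from compound 2 to compound 3 (within the scatter). Compound 3 is estimated at 45%, within 25% to 70%.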

Compound 3, largest response reached (reported as efficacy), in percent of the reference or control that the assay uses: 40%
Beside the measured number, compound 3's estimate is 5 percentage points above it; low and high end bracket the measured number.
By their numbers in this assay, from the lowest: compounds 2 and 3 (each within the scatter of the next); then compound 1.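

In this assay, fluoro on an aromatic carbon, meta to a large group, leaves the response within the scatter of the unsubstituted compound, with a number 3 percentage points higher from compound 2 to compound 3 (within the scatter), so this position takes a single fluoro group without a readable change. The 3-fluorophenyl group also does not bring back what the 2-cyanophenyl group gave: the step reads a number 31 percentage points lower from compound 1 to compound 3 (beyond the scatter), which keeps compound 3 with compound 2 and well apart from compound 1. The data offer no measurement that accounts for either step.

From the compounds shown here alone, whether a nitrile, a methoxy group or an amine at this same ring carbon would raise the response remains open. So does whether fluoro in the place the cyano group holds in compound 1 would behave as cyano does there.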